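Amide reversal from compound 1 to compound 4

The compounds below may be only part of what the source reports. "The series", "measured", "known", "first", "only" and "open" are said of these compounds alone.

Compound 1 `CC(=O)NCCCc1cccc2c1OCCO2`: 126 nM
Compound 2 `CC(=O)NCCCCc1cccc2c1SCCO2`: 126 nM
Compound 3 `COc1ccc2cccc(CCCC(N)=O)c2c1`: 20 nM

All three numbers come from an assay (Ovis aries) for binding affinity to melatonin receptor type 1A (Homo sapiens); on this read-out lower numbers stand for stronger inhibition and higher numbers for weaker inhibition. Compound 1 is level with compound 2 at the digits shown, and the two together give the highest numbers of the three; compound 3 gives a number below both, by a margin beyond the scatter. Compound 4 `CNC(=O)CCCc1cccc2c1OCCO2` has the same atoms as compound 1, joined differently: methylcarbamoyl in place of acetamido on a saturated chain carbon, three bonds along the chain from an aromatic carbon. Going by the values given here, no measured pair covers this change, so the step rests on compound 1 alone. It is expected to be small, in either direction or none beyond the scatter; the estimated step in this assay is a 1.3-fold higher number from compound 1 to compound 4 (0.10 log units; within the scatter). Compound 4 is therefore expected to give 160 nM, between 50 nM and 500 nM.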

Compound 4, half-maximal inhibitory concentration: 15.9 nM
For compound 4 the middle estimate is 10-fold (1.00 log units) above the measured one; the measured number lies below the stated range.
By their numbers in this assay, from the lowest: compounds 4 and 3 (each within the scatter of the next); then compounds 1 and 2 (each within the scatter of the next).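

In this assay, methylcarbamoyl in place of acetamido on a saturated chain carbon, three bonds along the chain from an aromatic carbon, gives a clear gain (a 7.9-fold lower number from compound 1 to compound 4 (0.90 log units; beyond the scatter)). Going by these compounds alone, with the same atoms joined differently, the orientation of the amide at this position therefore matters on the shared core, which the earlier compounds, with no pair differing in one place, could not show. No supporting data explain this shift. Still open, on these data alone, is whether ethylcarbamoyl or a primary carboxamide at this position, or a longer chain, holds this level.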